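The source may hold more compounds than are shown below. What is called first, only, known or untested is meant among the compounds shown, and "the series" means these compounds.

Within the data shown here, compound 1 `Nc1ccccc1-c1cc(F)cc(-n2nnc(-c3ccccn3)n2)c1` gives 8 nM in a functional assay for antagonist activity at metabotropic glutamate receptor 5 (Rattus norvegicus) (a higher number here means a weaker inhibitor, a lower number a stronger inhibitor), the lowest of the two numbers so far; its nearest neighbour is compound 2 `Nc1ccncc1-c1cc(F)cc(-n2nnc(-c3ccccn3)n2)c1`, which gives 108 nM in this assay. Replacing 2-aminophenyl with 4-aminopyridin-3-yl on an aromatic carbon produced a 14-fold higher number from compound 1 to compound 2 (1.13 log units; beyond the scatter). Compound 3 `Nc1cccnc1-c1cc(F)cc(-n2nnc(-c3ccccn3)n2)c1` differs from compound 1 thus: 3-aminopyridin-2-yl in place of 2-aminophenyl on an aromatic carbon. Among the measured compounds shown here, only the step to compound 2 bears on this change, and it was large. A smaller loss is expected for compound 3, since the entering group is a different aminopyridinyl, a 3.8-fold higher number from compound 1 to compound 3 (0.57 log units; beyond the scatter). Compound 3 is therefore estimated at 30 nM, ranging from 10 nM to 100 nM.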

Compound 3, half-maximal inhibitory concentration: 19 nM
Compound 3: middle estimate off by 1.6-fold (0.20 log units), on the high side; low and high end bracket the measured number.
By their numbers in this assay, from the lowest: compound 1; then compound 3; then compound 2.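

In this assay, 3-aminopyridin-2-yl in place of 2-aminophenyl gives only a 2.4-fold higher number from compound 1 to compound 3 (0.38 log units; beyond the scatter), so bringing in an aminopyridinyl group at this position need not cost as much as the earlier step suggested. Exchanging one aminopyridinyl group for the other gives a 5.7-fold lower number from compound 2 to compound 3 (0.75 log units; beyond the scatter), which shows that the two are not equivalent here. No evidence is available to explain this difference. The compounds shown leave open whether the amine is needed at this position, and whether a 2-hydroxyphenyl or 3-aminopyrazin-2-yl group would match 2-aminophenyl.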